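The source may report more compounds than this note shows. Statements on the series, on what has been measured and on what is new or still open speak of the compounds shown alone.

Compound 1: `C=CC(=O)NCCCCc1ccc2ncn(-c3ccnc(N)n3)c2c1`, 501000 nM. Compound 2: `C=Cc1ccnc(C#Cc2ccc3ncn(-c4ccnc(N)n4)c3c2)c1`, 1580 nM.

In an assay on Sf9 cells for inhibition of mitogen-activated protein kinase kinase kinase 14 variant S549D (Homo sapiens), with a stated time of 30 min, in the presence of a further agent that is not named here (a higher number here means a weaker inhibitor, a lower number a stronger inhibitor), compound 2 has the lowest of the two numbers; compound 1 sits a long way higher, well beyond the scatter. Compound 3, `C#Cc1cc(C#Cc2ccc3ncn(-c4ccnc(N)n4)c3c2)ncn1`, differs from compound 2 by a group of 8 heavy atoms (6 carbon, 2 nitrogen; one six-membered aromatic ring with 2 hetero atoms) in place of a group of 8 heavy atoms (7 carbon, 1 nitrogen; one six-membered aromatic ring with 1 hetero atom), on a triple-bonded carbon. Within the data shown here, no step between measured compounds of this kind is known, so the direction of the change is uncertain; with the triple-bonded link kept, the step is expected to stay within, or only a little beyond, the scatter. Compound 3 is therefore expected to give about 2000 nM in this assay, within 500 nM to 8000 nM, which would be a step of a 1.3-fold higher number from compound 2 to compound 3 (0.10 log units; within the scatter).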

Compound 3, half-maximal inhibitory concentration: 50100 nM
Beside the measured number, compound 3's estimate is 25-fold (1.40 log units) below it, outside the stated range (above it).
By their numbers in this assay, from the lowest: compound 2; then compound 3; then compound 1.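

At the triple-bonded carbon, this assay proves sensitive to the ring itself: with the heavy-atom count unchanged, the exchange gives a 32-fold higher number from compound 2 to compound 3 (1.50 log units; beyond the scatter) in a large step. The change has two parts, since the entering group has 2 hetero atoms in its ring and a triple bond outside it, where the leaving group has 1 hetero atom and a double bond. Nothing measured here accounts for the step.

Which of these two differences carries the step stays open. So does how an amine or a carboxylic acid on the same triple-bonded carbon would compare.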